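The source may hold more compounds than are shown below. What is called first, only, known or untested is meant among the compounds shown, and "the series" means these compounds.

In a functional assay on B16 cells (Mus musculus) for cytotoxicity, read by MTT assay, with a stated time of 72 h (a lower number here means a stronger inhibitor, a higher number a weaker inhibitor), the measured compounds give these numbers:

compound 1, `CN(C)CCCOc1c(OCc2ccccc2)cc(O)c2c(=O)cc(-c3ccccc3)oc12`: 5420 nM
compound 2, `CN1CCN(CCCCOc2c(OCc3ccccc3)cc(O)c3c(=O)cc(-c4ccccc4)oc23)CC1`: 2370 nM
compound 3, `Cc1ccc(COc2cc(O)c3c(=O)cc(-c4ccccc4)oc3c2OCCCCN2CCN(C)CC2)cc1`: 3290 nM

Compound 3 stands second highest of the three numbers. Its nearest neighbour is compound 2, and the step of a 1.4-fold higher number from compound 2 to compound 3 (0.14 log units; within the scatter) lies within the scatter. Among the compounds with values here, no step is computed between compound 1 and compound 3; compound 1 gives 5420 nM and compound 3 gives 3290 nM, a gap that is also within the scatter. All three compounds therefore sit close together in this assay.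

Compound 4, `CN1CCN(CCCCOc2c(OCc3ccco3)cc(O)c3c(=O)cc(-c4ccccc4)oc23)CC1`, differs from compound 3 in one place: furan-2-yl in place of 4-methylphenyl on a saturated chain carbon bound to an oxygen on an aromatic ring. Within the data shown here, only one measured step touches the same part of the molecule, the step of a 1.4-fold higher number from compound 2 to compound 3 (0.14 log units; within the scatter), which added a methyl to that ring and did not move the number beyond the scatter. The other step, a 2.3-fold lower number from compound 1 to compound 2 (0.36 log units; beyond the scatter), changes the amine at the end of the chain and does not bear on an exchange of the aromatic ring. Among the measured compounds shown here, no measured pair swaps the ring itself, so the expectation rests on the quiet response of this position so far. Compound 4 is therefore expected to show a step of a 1.1-fold lower number from compound 3 to compound 4 (0.04 log units; within the scatter), none beyond the scatter. For compound 4 the estimate in this assay is 3000 nM, with a range from 1200 nM to 7500 nM.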

Compound 4, half-maximal inhibitory concentration: 3530 nM
Compound 4: the middle estimate sits 1.2-fold (0.07 log units) below what was measured; low and high end bracket the measured number.
By their numbers in this assay, from the lowest: compounds 2, 3, 4 and 1 (each within the scatter of the next, the first and the last beyond it).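

In this assay, within the data shown here, the step of a 1.1-fold higher number from compound 3 to compound 4 (0.03 log units; within the scatter) and the step of a 1.5-fold higher number from compound 2 to compound 4 (0.17 log units; within the scatter) are the first measured exchanges of the aromatic ring itself on a saturated chain carbon bound to an oxygen on an aromatic ring, and both lie within the scatter. The earlier compounds had shown only that a methyl on this ring left the number within the scatter, whereas compound 4 shows the same for replacing the six-membered aromatic ring of carbon only with a five-membered aromatic ring with 1 hetero atom, a change that also brings in a hydrogen-bond acceptor. Across compound 2, compound 3 and compound 4 this position therefore gives no step beyond the scatter, although nothing measured here explains that flat response.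

As far as these compounds go, all of these ring exchanges carry the same (4-methylpiperazin-1-yl) chain end, so it remains open whether they would read the same way on the dimethylamino chain of compound 1. From the compounds shown here alone, it also remains open whether the position stays this quiet with a pyridin-3-yl ring, a carboxylic acid on the phenyl ring, or a plain methyl in place of any ring.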